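Cytotoxicity notes: hydroxyphenyl to hydroxy-methoxyphenyl hydrazone

This account rests on a few compounds, and the source may have more. Where it says the series, first, only, none or still open, it means among the compounds named here.

Going by the values given here, compound 1 `CN(C)CCn1cnnc1-c1cc(Oc2ccc(NC(=O)N/N=C/c3cccc(Cl)c3Cl)cc2F)ccn1` in an ADME assay on WI-38 cells (Homo sapiens) for cytotoxicity, read by MTT assay, with a stated time of 72 h (a higher number here means a weaker inhibitor, a lower number a stronger inhibitor), gives 6130 nM, the only number so far. Compound 2 `CN(C)CCn1cnnc1-c1cc(Oc2ccc(NC(=O)N/N=C/c3ccc(O)cc3)cc2F)ccn1` in this assay gives "not determined" (no result reported), so there is no anchor for the next step. Compound 3 `COc1cc(/C=N/NC(=O)Nc2ccc(Oc3ccnc(-c4nncn4CCN(C)C)c3)c(F)c2)ccc1O` differs from compound 2 by methoxy in place of hydrogen on an aromatic carbon. Among the compounds with values here, with no measured pair to set the scale, no step beyond the usual scatter is expected in this assay in either direction. Compound 3 is therefore expected to lie near 15000 nM, within a range of 4000 nM to 50000 nM, with a real chance that only a limit is reported.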

Compound 3, half-maximal inhibitory concentration: 5320 nM
For compound 3 the middle estimate is 2.8-fold (0.45 log units) above the measured one; low and high end bracket the measured number.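

In this assay the carbon with a double bond to nitrogen now has a first readable step: 4-hydroxy-3-methoxyphenyl in place of 2,3-dichlorophenyl gives a 1.2-fold lower number from compound 1 to compound 3 (0.06 log units; within the scatter) and so does not separate these two groups. The step from compound 2 to compound 3 cannot be read, which leaves the methoxy without a measured size of its own. No supporting measurement bears on this result.

Open, on these data alone, is whether an amine or a longer alkoxy chain in place of the methoxy would give a step beyond the scatter in this assay.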